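A few compounds are considered here, and "the series" means these few. Any claim that something is new, unique, unknown or untested is made for them only; others in the source may bear on it.

Measured so far in an assay (Cricetulus griseus) for inhibition of aldehyde dehydrogenase, mitochondrial (Homo sapiens); a higher number here means a weaker inhibitor, a lower number a stronger inhibitor:
- compound 1 `O=C(O)CCCCCCCCCCCCCCCOc1ccc2c(=O)c(-c3ccc(O)cc3)coc2c1`: > 9000 nM
- compound 2 `CCCCC(Oc1ccc2c(=O)c(-c3ccc(O)cc3)coc2c1)C(=O)OCC`: 4500 nM

Compound 1 sits at the edge of what this assay reports. In this assay compound 1 gives > 9000 nM, which is a limit of the assay and not a number (the limit of > 9000 nM in this assay, at which 1 of the 2 values shown sits). Within the data shown here, compound 2, carrying a shorter chain ending in an ester rather than an acid, gives 4500 nM in this assay; no step between compound 1 and compound 2 is computed here, and the two values show only that both lie in the weak range.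

Compound 3 `O=C(O)CCCCCCCCCCCOc1ccc2c(=O)c(-c3ccc(O)cc3)coc2c1` is the next member to be measured. It differs from compound 1 as follows: carboxy in place of 4-carboxybutyl on a saturated chain carbon, ten or more bonds along the chain from an oxygen on an aromatic ring. The chain is thus cut back by several carbons while the terminal acid is kept.

With compound 1 known only as a limit, the step to compound 3 cannot be anchored; the expectation is for a change no larger than the scatter, in no clear direction, so that the expected step of an at least 1.1-fold lower number from compound 1 to compound 3 (0.05 log units; that floor lies within the scatter) is small. Compound 3 is accordingly expected at about 8000 nM, within 3000 nM to 20000 nM, with a fair chance that only a limit is returned again.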

Compound 3, half-maximal inhibitory concentration: 130 nM
The estimate for compound 3 lay 62-fold (1.79 log units) above the measured number; measured number outside the range, below it.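

In this assay, replacing 4-carboxybutyl with carboxy on a saturated chain carbon gives an at least 69-fold lower number from compound 1 to compound 3 (1.84 log units; beyond the scatter), so with the terminal acid and the shared core unchanged, cutting the chain back is enough to produce a step beyond the scatter, something the first two compounds could not show. Compound 1 gives > 9000 nM in this assay, which is a limit of the assay and not a number. The printed step is therefore a floor and its true size remains unknown, because compound 1 sits at that limit: the limit of > 9000 nM in this assay, at which 1 of the 3 values shown sits.

From the compounds shown here alone, two acid-ended chains fix no trend, so it remains open whether inhibition keeps strengthening as the chain shortens further or peaks at some other length. Going by these compounds, it also remains open whether the terminal acid itself matters at this chain length, and a primary amide or a primary alcohol at the chain end of compound 3 would test that directly.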